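This account rests on a few compounds, and the source may have more. Where it says the series, first, only, none or still open, it means among the compounds named here.

Compound 1 `Cc1ccc(CNC(=O)c2[nH]c3ccc(Cl)cc3c2S(=O)(=O)c2cc(C)cc(C)c2)cc1`: 21200 nM
Compound 2 `COc1ccc(CNC(=O)c2[nH]c3ccc(Cl)cc3c2S(=O)(=O)c2cc(C)cc(C)c2)cc1`: 39900 nM

In an ADME assay on MT4 cells (Homo sapiens) for cytotoxicity, read by MTT assay (on this read-out higher numbers stand for lower toxicity in this test and lower numbers for higher toxicity in this test), compound 1 gives 21200 nM, the lowest of the two numbers; compound 2 gives 39900 nM, and the step of a 1.9-fold higher number from compound 1 to compound 2 (0.27 log units; within the scatter) lies within the scatter, so the two are not separated.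

Compound 3 `Cc1cc(C)cc(S(=O)(=O)c2c(C(=O)NCc3ccc([N+](=O)[O-])cc3)[nH]c3ccc(Cl)cc23)c1` is not yet measured in this assay. It differs from compound 1 by nitro in place of methyl on an aromatic carbon. Among the measured compounds shown here, the only measured step, a 1.9-fold higher number from compound 1 to compound 2 (0.27 log units; within the scatter), replaces the same methyl and stayed within the scatter; no measured step covers nitro in place of methyl. The step of a 1.2-fold higher number from compound 1 to compound 3 (0.07 log units; within the scatter) is therefore expected to stay within the scatter. For compound 3 the estimate in this assay is 25000 nM, with a range of 8000 nM to 80000 nM.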

Compound 3, half-maximal cytotoxic concentration: > 50200 nM
Compound 3: no number, only a limit; the forecaster's own chance of this, stated with the estimate: 10%; at least 2.0-fold (0.30 log units) between middle value and limit.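

In this assay compound 3 gives a limit and not a number: the limit of > 50200 nM in this assay, at which 1 of the 3 values shown sits.

Among the compounds shown here, changing 4-methylbenzyl to 4-nitrobenzyl gives an at least 2.3-fold higher number from compound 1 to compound 3 (0.37 log units; beyond the scatter), the first step at this position to clear the scatter, so this position does respond to a change of group in this test. The other step, an at least 1.2-fold higher number from compound 2 to compound 3 (0.09 log units; that floor lies within the scatter), rests on a floor only, so nitro is not separated from methoxy here.

From the compounds shown here alone, the true number for compound 3 stays open. Also open, going by these compounds, is whether an amine or a carboxylic acid at this position would read closer to methyl or to nitro.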